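Swapping a Difluorophenyl Ring for an Aminopyridine

The compounds below may be only part of what the source reports. "The series", "measured", "known", "first", "only" and "open" are said of these compounds alone.

Three measured compounds share one core, and compound 1 `O=C(O)Cc1sc(C(c2ccc(F)cc2)c2ccc(F)cc2)nc1-c1cc(F)cc(F)c1` is the starting point here. In an in vitro functional assay on HEK285-7 cells for antagonist activity at prostaglandin D2 receptor 2 (Homo sapiens), read by BRET and beta-arrestin recruitment (a lower number here means a stronger inhibitor, a higher number a weaker inhibitor), compound 1 gives 340 nM, the lower of the two numbers recorded so far. Compound 3 `O=C(O)Cc1sc(C(c2ccccc2)c2ccccn2)nc1-c1ccc(Cl)cc1` gives 1900 nM in this assay, and that gap lies beyond the usual scatter, so compound 1 stands clearly lower than compound 3. Compound 2 `O=C(O)Cc1sc(C(c2ccccc2)c2ccccc2)nc1-c1ccc(C(F)(F)F)cc1` reaches only a limit of this assay, > 100000 nM, and no number is reported for it (the limit of > 100000 nM in this assay, at which 1 of the 3 values shown sits).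

Compound 4 `CN(C)c1cc(-c2nc(C(c3ccc(F)cc3)c3ccc(F)cc3)sc2CC(=O)O)ccn1` has not yet been measured. It differs from compound 1 in one place (2-(dimethylamino)pyridin-4-yl in place of 3,5-difluorophenyl on an aromatic carbon). For the measured compounds named here, none of the measured pairs shows an exchange of this kind, so the three values give no direct guide to its size. The expected step is therefore modest, most likely no larger than the usual scatter or a little beyond it, and its direction is uncertain, with a slight lean toward a weaker compound. Compound 4 is estimated to give 500 nM in this assay, with a range from 100 nM to 3000 nM. The step this estimate means is expected to be a 1.5-fold higher number from compound 1 to compound 4 (0.17 log units; within the scatter).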

Compound 4, half-maximal inhibitory concentration: > 100000 nM
Compound 4: no number, only a limit; the forecaster's own chance of this, stated with the estimate: 10%; middle value at least 200-fold (2.30 log units) from the limit.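

Putting 2-(dimethylamino)pyridin-4-yl in place of 3,5-difluorophenyl brings an at least 290-fold higher number from compound 1 to compound 4 (2.46 log units; beyond the scatter) in this assay, so this aromatic carbon of the core does not accept every six-membered aromatic ring. With the rest of compound 1 unchanged, this one exchange is enough to leave no measurable number. Compound 4 gives > 100000 nM, which is a limit and not a number, so the step has a known lower bound but no known upper end: the limit of > 100000 nM in this assay, at which 2 of the 4 values shown sit.

The exchange changes several things at once, as a carbon-only ring bearing two fluorine atoms gives way to a ring with a hetero atom and a dimethylamino group, and the compounds shown cannot tell which of these matters. A plain pyridin-4-yl group, or a 2-aminopyridin-4-yl group with a primary amine in place of the dimethylamino group, would help to separate the effect of the ring nitrogen from that of the two methyl groups.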